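The compounds below may be only part of what the source reports. "The series", "measured", "known", "first", "only" and "open" are said of these compounds alone.

Measured so far:
- compound 1, `Cc1c(OCCCCOc2ccccc2C(=O)O)ccc(C(=O)CC2CCCC2)c1C`: 28%
- compound 2, `Cc1c(OCCCCOc2ccc(C(=O)O)cc2Cl)ccc(C(=O)CC2CCCC2)c1O`: 27.4%
- compound 3, `Cc1c(OCCCCOc2ccc(C(=O)CC(C)(C)C)c(O)c2C)cccc1C(=O)O`: 109%

In an assay on HEK293 cells for positive allosteric modulation of metabotropic glutamate receptor 3 (Rattus norvegicus), read by thallium flux, with a stated time of 2.5 min (a higher number here means a larger maximal response, a lower number a smaller maximal response), compound 2 gives 27.4%, the lowest of the three numbers. Compound 1 gives 28%, a number within the usual scatter of compound 2, so the two cannot be told apart. Compound 3 gives 109%, far beyond the scatter above compound 2, though compound 3 differs from compound 2 in more than one place, so no single change can be credited for that gap.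

Compound 4, `Cc1cc(OCCCCOc2ccc(C(=O)CC3CCCC3)c(O)c2C)ccc1C(=O)O`, differs from compound 2 in one place: 4-carboxy-3-methylphenyl in place of 4-carboxy-2-chlorophenyl on an oxygen on a saturated carbon

Among the measured compounds shown here, no pair of measured compounds that differ in one place is available, so the size of this step is open. For the measured compounds named here, the only higher number seen, that of compound 3, also carries a carboxylic acid with a methyl on the same ring, which leans the expectation upward, but a modest rise is the most that can be estimated. For compound 4 the expected value in this assay is 45%, with a range from 20% to 90%, which is expected to correspond to a step of a number 17.6 percentage points higher from compound 2 to compound 4 (beyond the scatter).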

Compound 4, largest response reached (reported as percent of maximum), in percent of the reference or control that the assay uses: 23.7%
Compound 4: the middle estimate sits 21.3 percentage points above what was measured, and the stated range covers the measured number.
By their numbers in this assay, from the lowest: compounds 4, 2 and 1 (each within the scatter of the next); then compound 3.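

Among the compounds shown here, this is the first comparison in the set that changes only one thing: 4-carboxy-3-methylphenyl replaces 4-carboxy-2-chlorophenyl on an oxygen on a saturated carbon. In this assay the step is a number 3.7 percentage points lower from compound 2 to compound 4 (within the scatter), so the two compounds cannot be told apart, and at this position the exchange of these two rings gives no measurable difference in maximal response. Nothing measured here explains this result.

Still open, going by these compounds, is whether a different group on this ring, such as a fluorine or a methoxy, would give a response distinguishable from these two. It is also unknown whether replacing the carboxylic acid with an amine, or using a longer chain to carry the ring, would move the response at all.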